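Swapping isopropyl for cyclopentyl in an allosteric modulator series

The compounds below may be only part of what the source reports. "The series", "measured", "known", "first", "only" and "open" are said of these compounds alone.

Of the compounds shown here, two have been measured in an assay on HEK293 cells for positive allosteric modulation of metabotropic glutamate receptor 2 (Rattus norvegicus), read by thallium flux, with a stated time of 2.5 min; on this read-out lower numbers stand for smaller maximal responses and higher numbers for larger maximal responses. Compound 1, with the structure `Cc1ccc(C(=O)O)cc1OCCCCOc1ccc(C(=O)CC2CCCC2)c(O)c1C`, gives 67.5%. Compound 2, with the structure `Cc1c(OCCCCOc2ccc(F)c(C(=O)O)c2)ccc(C(=O)CC(C)C)c1O`, gives 84.5% in this assay, the higher of the two numbers, standing above compound 1 by a gap beyond the usual scatter. These two differ in several places at once, so their values show only where each stands, not what any single change does.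

Compound 3, with the structure `Cc1c(OCCCCOc2ccc(F)c(C(=O)O)c2)ccc(C(=O)CC2CCCC2)c1O`, has not yet been measured. It differs from compound 2 in one place: cyclopentyl in place of isopropyl on a saturated chain carbon bound to a carbonyl carbon. Among the measured compounds shown here, no measured pair shows this change alone. Compound 1 carries the same cyclopentyl group and sits lower, but it also differs elsewhere, so only a modest step is expected. The step from compound 2 to compound 3 is estimated as a number 6.5 percentage points lower from compound 2 to compound 3 (within the scatter), within the scatter or slightly downward. Compound 3 is therefore expected to give 78%, with a range from 60% to 95%.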

Compound 3, largest response reached (reported as percent of maximum), in percent of the reference or control that the assay uses: 81%
For compound 3 the middle estimate is 3 percentage points below the measured one; low and high end bracket the measured number.
By their numbers in this assay, from the lowest: compound 1; then compounds 3 and 2 (each within the scatter of the next).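

In this assay replacing isopropyl with cyclopentyl on the saturated chain carbon bound to a carbonyl carbon gives a number 3.5 percentage points lower from compound 2 to compound 3 (within the scatter) and so shows that this position accepts the five-membered ring with no clear change in maximal response. With cyclopentyl held in place, 3-carboxy-4-fluorophenyl in place of 5-carboxy-2-methylphenyl on an oxygen on a saturated carbon gives a number 13.5 percentage points higher from compound 1 to compound 3 (beyond the scatter) and so ties the lower number of compound 1 to that aryl group, not to cyclopentyl. Nothing measured here gives a reason for either step.

From the compounds shown here alone, it remains open whether a cyclohexyl ring or a longer chain such as n-pentyl would also be accepted at this position. Also open, going by these compounds, is whether isopropyl and cyclopentyl would stay this close when paired with the 5-carboxy-2-methylphenyl group.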